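The source may report more compounds than this note shows. Statements on the series, on what has been measured and on what is new or still open speak of the compounds shown alone.

Working notes on the aminoquinoline–thiophene series

Three compounds have been run in an ADME assay on PBMC cells (Homo sapiens) for cytotoxicity, read by MTT assay, with a stated time of 48 h (a higher number here means a weaker inhibitor, a lower number a stronger inhibitor), so far. Compound 1, `N#Cc1ccc(-c2ccc(CNCCNc3ccnc4cc(Cl)ccc34)s2)cc1`, gives 26100 nM. Compound 3, `Clc1ccc2c(NCCNCc3ccc(-c4cccnc4)s3)ccnc2c1`, gives 16400 nM. Compound 2, `N#Cc1ccc(-c2ccc(CNCCCNc3ccnc4cc(Cl)ccc34)s2)cc1`, gives 3550 nM and stands lowest of the three numbers; its distance to compound 3 and to compound 1 is in each case beyond the scatter, so compound 2 is the strongest inhibitor of the measured set. The difference between the core of compound 1 and the core of compound 2 is not broken down here.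

Among the compounds with values here, the one change that has been measured directly is pyridin-3-yl in place of 4-cyanophenyl on an aromatic carbon. It produced a 1.6-fold lower number from compound 1 to compound 3 (0.20 log units; within the scatter), a step that stays within the scatter, so in this assay the 4-cyanophenyl and the pyridin-3-yl compound cannot be told apart.

Compound 4, `Clc1ccc2c(NCCCNCc3ccc(-c4cccnc4)s3)ccnc2c1`, has not yet been measured in this assay. Within the data shown here, it arises from compound 2 by pyridin-3-yl in place of 4-cyanophenyl on an aromatic carbon, the same change as the one from compound 1 to compound 3, at a place described in identical words. Because a 1.6-fold lower number from compound 1 to compound 3 (0.20 log units; within the scatter) lay within the scatter, the expected step is a 1.5-fold lower number from compound 2 to compound 4 (0.19 log units; within the scatter), and it rests on that single earlier pair only. Compound 4 is therefore expected to come out at about 2300 nM, with a plausible range from 1000 nM to 6000 nM.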

Compound 4, half-maximal inhibitory concentration: 21600 nM
Compound 4: middle estimate off by 9.4-fold (0.97 log units), on the low side; measured number outside the range, above it.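

In this assay, pyridin-3-yl in place of 4-cyanophenyl on an aromatic carbon gives a 6.1-fold higher number from compound 2 to compound 4 (0.78 log units; beyond the scatter), and this does not repeat the earlier result for the same change: the same change on two cores in this assay, a 1.6-fold lower number (0.20 log units; within the scatter) from compound 1 to compound 3 and a 6.1-fold higher number (0.78 log units; beyond the scatter) from compound 2 to compound 4, 9.7-fold (0.99 log units) apart, beyond the scatter of two such steps. Within these two pairs, the outcome of the change therefore depends on the core that carries it, and a step read on the core of compound 1 cannot be transferred to the core of compound 2. The pairs do not show which feature of the two cores sets the steps apart, and two pairs give no rule for how the change will behave on any further core.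

Still open, from the compounds shown here alone, is how the same change behaves on a core with a longer chain, which would show whether the step from the core of compound 2 persists or reverts to a step within the scatter. Also open, going by these compounds, is whether a phenyl ring bearing a carboxylic acid or a primary amine in place of the nitrile would behave like 4-cyanophenyl or like pyridin-3-yl on these two cores.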